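Amino in place of hydrogen on the core of compound 2

This account rests on a few compounds, and the source may have more. Where it says the series, first, only, none or still open, it means among the compounds named here.

Measured compounds:
compound 1 `ClCc1ccccc1Cn1cnc2c(Cl)nc(Cl)nc21`: 1820 nM
compound 2 `ClCc1ccccc1Cn1cnc2c(Cl)ncnc21`: reported only as a limit, > 100000 nM
compound 3 `ClCc1ccc(Cn2cnc3c(Cl)nc(Cl)nc32)cc1`: 3980 nM

In a functional assay on MCF7 cells (Homo sapiens) for cytotoxicity, read by sulforhodamine B assay, with a stated time of 48 h (a lower number here means a stronger inhibitor of growth, a higher number a weaker inhibitor of growth), compound 1 gives 1820 nM and compound 3 gives 3980 nM; both lie well inside the measurable range. Compound 2 sits at the limit of > 100000 nM in this assay, at which 1 of the 3 values shown sits, so no number is known for it, only that limit. Among the compounds with values here, the single measured step, an at least 54-fold higher number from compound 1 to compound 2 (1.73 log units; beyond the scatter), is the loss seen when hydrogen replaces chloro on the core; its true size is unknown because compound 2 is a limit.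

Compound 4 `Nc1nc(Cl)c2ncn(Cc3ccccc3CCl)c2n1` carries amino in place of hydrogen on an aromatic carbon. This is the same position at which the step from compound 1 to compound 2 was taken, but with amino rather than chloro entering, so that step bears on it only indirectly: it shows that a substituent at this position is tied to a large difference in this assay, without telling what amino does there. The step from compound 2 to compound 4 is therefore expected to give a lower number, of uncertain size, an at least 3.3-fold lower number from compound 2 to compound 4 (0.52 log units; beyond the scatter). For compound 4 an estimate of 30000 nM, within 5000 nM to 150000 nM, is set down, with a real chance that the assay again reports only a limit.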

Compound 4, concentration for total growth inhibition: 24600 nM
Estimate against measurement, compound 4: 1.2-fold (0.09 log units) above; the measured number falls inside the stated range.
By their numbers in this assay, from the lowest: compound 1; then compound 3; then compound 4. At a limit, above all of these: compound 2.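

In this assay, the position between two ring nitrogen atoms now has a second substituent with a measured value, and amino in place of hydrogen gives an at least 4.0-fold lower number from compound 2 to compound 4 (0.60 log units; beyond the scatter). Going by these compounds, compound 2 is held only at a limit, so the true size of that step remains unknown: the limit of > 100000 nM in this assay, at which 1 of the 4 values shown sits. Amino does not stand in fully for chloro at this position, since amino in place of chloro gives a 14-fold higher number from compound 1 to compound 4 (1.13 log units; beyond the scatter), which places the measured compounds with a substituent here in the order of compound 1, then compound 4.

On these data alone, whether a methoxy group or a dimethylamino group at this position would fall nearer to compound 1 or to compound 4 stays open. As far as these compounds go, it is also open whether amino in place of chloro on the core of compound 3 would give a step of similar size.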